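Fluorine placement on the acid chain at the rat receptor

The compounds below may be only part of what the source reports. "The series", "measured", "known", "first", "only" and "open" are said of these compounds alone.

Compound 1 `Cc1cccc(C)c1-c1cccc(COc2ccc(CC(F)C(=O)O)cn2)c1` and compound 2 `Cc1cccc(C)c1-c1cccc(COc2ccc(CC(C)C(=O)O)cn2)c1` share a core and differ only in the group on a saturated chain carbon bound to the carbonyl carbon. In a functional assay on CHO cells for agonist activity at Free fatty acid receptor 1 (Rattus norvegicus), read by calcium flux (on this read-out higher numbers stand for an effect only at larger amounts of compound and lower numbers for an effect already at smaller amounts), compound 1 gives 250 nM, while compound 2 gives 2100 nM. Going by the values given here, compound 2 thus holds the highest number of the two, and the only step measured so far, an 8.4-fold higher number from compound 1 to compound 2 (0.92 log units; beyond the scatter), shows what replacing fluoro by methyl at that carbon costs.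

Compound 3 `Cc1cccc(C)c1-c1cccc(COc2ccc(C(F)CC(=O)O)cn2)c1` is the unmeasured member. Relative to compound 2 the change is 2-carboxy-1-fluoroethyl in place of 2-carboxypropyl on an aromatic carbon. Fluorine returns to the chain, though within a differently named group than in compound 1, so the step from compound 1 to compound 2 bears on it only by analogy: the methyl group that gave compound 2 its higher number is gone and a fluorine is present again. Compound 3 is therefore expected to land below compound 2 in this assay, with a step of roughly a 3.5-fold lower number from compound 2 to compound 3 (0.54 log units; beyond the scatter), and its value is estimated at 600 nM within a range of 150 nM to 2400 nM.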

Compound 3, half-maximal effective concentration: 96 nM
For compound 3 the middle estimate is 6.3-fold (0.80 log units) above the measured one, outside the stated range (below it).
By their numbers in this assay, from the lowest: compound 3; then compound 1; then compound 2.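

Fluorine's place on the chain matters as well as its presence: compounds 1 and 3 both carry a fluorinated chain, yet 2-carboxy-1-fluoroethyl in place of 2-carboxy-2-fluoroethyl gives a 2.6-fold lower number from compound 1 to compound 3 (0.42 log units; beyond the scatter) in this assay. The other new step, a 22-fold lower number from compound 2 to compound 3 (1.34 log units; beyond the scatter), spans more than the earlier fluoro-to-methyl comparison could show, and compound 3 now has the lowest number of the three, with its steps to both others beyond the scatter. Nothing available explains why moving the fluorine or replacing the 2-carboxypropyl group shifts the number in this way.

The compounds shown do not separate the effect of the fluorine in 2-carboxy-1-fluoroethyl from that of the altered chain, since compound 3 has no direct partner carrying a hydrogen, a methyl or a hydroxyl group in the fluorine's place. They also leave open how a second fluorine on the same carbon or a longer chain before the carboxylic acid would behave in this assay.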